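The compounds below may be only part of what the source reports. "The series", "measured", "known", "first", "only" and "open" are said of these compounds alone.

Of the compounds shown here, two sharing one core have so far been measured in an assay on cells for inhibition of Voltage-dependent T-type calcium channel subunit alpha-1H (Homo sapiens), read by FLIPR and calcium flux, with stated times of 600 s and 300 s; a higher number here means a weaker inhibitor, a lower number a stronger inhibitor. Compound 1 `CN(Cc1ccc(OCCCNC(=N)N)cc1)c1nc2ccc(Oc3ccc(C(F)(F)F)cc3)cc2s1` gives 212000 nM, and compound 2 `CN(Cc1ccc(OCCCNC(=N)N)cc1)c1nc2ccc(Oc3ccc(O)cc3)cc2s1` gives 332000 nM. Of these two numbers compound 2 has the higher one, yet the step of a 1.6-fold higher number from compound 1 to compound 2 (0.19 log units; within the scatter) is within the scatter, so the two compounds cannot really be told apart on this evidence. Compound 3 `CN(Cc1ccc(OCCCNC(=N)N)cc1)c1nc2ccc(Oc3cccc(C(F)(F)F)c3)cc2s1` has not yet been measured. It differs from compound 2 by 3-(trifluoromethyl)phenyl in place of 4-hydroxyphenyl on an oxygen on an aromatic ring. Among the compounds with values here, the only measured step that bears on this change is the one from compound 1 to compound 2, in which hydroxy replaced trifluoromethyl, and that step was small; compound 3 brings the trifluoromethyl group back, though as 3-(trifluoromethyl)phenyl rather than the group seen in compound 1. Because a 1.6-fold higher number from compound 1 to compound 2 (0.19 log units; within the scatter) lies within the scatter, no step beyond the scatter is expected for compound 3 either, and the estimated step is a 1.4-fold lower number from compound 2 to compound 3 (0.16 log units; within the scatter). Compound 3 is therefore expected at 230000 nM, within a range from 100000 nM to 520000 nM.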

Compound 3, half-maximal inhibitory concentration: 771000 nM
Compound 3: the middle estimate sits 3.4-fold (0.53 log units) below what was measured; measured number above the stated range.
By their numbers in this assay, from the lowest: compounds 1 and 2 (each within the scatter of the next); then compound 3.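

In this assay, the place of the trifluoromethyl group on this ring turns out to matter: 3-(trifluoromethyl)phenyl in place of 4-(trifluoromethyl)phenyl gives a 3.6-fold higher number from compound 1 to compound 3 (0.56 log units; beyond the scatter), whereas the earlier swap of trifluoromethyl for hydroxy stayed within the scatter. The change from 4-hydroxyphenyl to 3-(trifluoromethyl)phenyl also gives a modest step, a 2.3-fold higher number from compound 2 to compound 3 (0.37 log units; beyond the scatter), so this position on the oxygen does respond to the group it carries, and simply having a trifluoromethyl group there does not settle the result. Nothing available here accounts for these steps.

The compounds shown leave open how an amine, a carboxylic acid or a methoxy group would behave in place of the trifluoromethyl group. They also leave open whether any group at this position could give a clearly lower number than the three seen so far.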